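The compounds below may be only part of what the source reports. "The series", "measured", "known", "first", "only" and "open" are said of these compounds alone.

Series notes, shared core with two 4-methoxyphenyl groups on the five-membered ring; the variable group sits on the remaining aromatic carbon.

Compound 1 `COc1ccc(-c2nc(/N=C(\N)NC(C)C)sc2-c2ccc(OC)cc2)cc1` carries a substituted guanidine-type group there. In a functional assay with Oryctolagus cuniculus as the target (a lower number here means a stronger inhibitor, a higher number a weaker inhibitor), compound 1 gives only a limit, > 100 nM, so its standing among the three measured compounds is known from one side only. Compound 2 `COc1ccc(-c2nc(/N=C(\N)NC3CCCCC3)sc2-c2ccc(OC)cc2)cc1` also returns a limit in this assay, > 1000 nM. Within the data shown here, compound 3 `COc1ccc(-c2nc(CNC(=O)CSC)sc2-c2ccc(OC)cc2)cc1` returns a limit as well, < 100 nM, the one value that sits on the potent side. The step that the two limits leave unreadable from compound 1 to compound 2 cannot be read from the two limits. Among the measured compounds shown here, the step of a number no higher from compound 1 to compound 3 (the limit leaves the size open) is open in size, while an at least 10-fold lower number from compound 2 to compound 3 (1.00 log units; beyond the scatter) is the one readable step and it favours the amide-linked methyl group.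

Compound 4 `COc1ccc(-c2nc(CNC(=O)NC(C)C)sc2-c2ccc(OC)cc2)cc1` follows the same direction as compound 3: a group of 8 heavy atoms (5 carbon, 2 nitrogen, 1 oxygen; no ring) in place of a group of 7 heavy atoms (4 carbon, 3 nitrogen; no ring), on an aromatic carbon; the urea in compound 4 resembles the carbonyl-bearing chain of compound 3 more than the guanidine of compound 1. Both steps that swap the guanidine for a carbonyl-bearing chain, a number no higher from compound 1 to compound 3 (the limit leaves the size open) and an at least 10-fold lower number from compound 2 to compound 3 (1.00 log units; beyond the scatter), point to a lower number, so a step in that direction, an at least 1.6-fold lower number from compound 1 to compound 4 (0.22 log units; that floor lies within the scatter), is expected. Compound 4 is accordingly estimated at 60 nM in this assay, within 15 nM to 300 nM, with a fair chance that only a limit is reported again.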

Compound 4, half-maximal inhibitory concentration: 42 nM
Estimate against measurement, compound 4: 1.4-fold (0.15 log units) above, and the stated range covers the measured number.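

The ((isopropylcarbamoyl)amino)methyl group on this aromatic carbon gives the series its first value in this assay that is not a limit, and the change from the guanidine-type groups can now be sized: an at least 2.3-fold lower number from compound 1 to compound 4 (0.37 log units; beyond the scatter), and an at least 23-fold lower number from compound 2 to compound 4 (1.37 log units; beyond the scatter). Both sizes are floors, since compound 1 and compound 2 are known only as limits, yet the floor from compound 1 already lies beyond the scatter, which the open-ended comparison of compound 1 with compound 3 could not show. Compound 1 and compound 4 both carry an isopropyl group, so the readable gap goes with the exchange of the guanidine-type group for the urea-bearing chain and not with a change of that end group.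

The step that joins compound 3 and compound 4 cannot be read because compound 3 is known only as a limit: the limit of < 100 nM in this assay, at which 1 of the 4 values shown sits. Also open, as far as these compounds go, is how a longer chain, a free amine or a carboxylic acid in place of the ((isopropylcarbamoyl)amino)methyl group would read in this assay.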